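A few compounds are considered here, and "the series" means these few. Any claim that something is new, unique, unknown or untested is made for them only; others in the source may bear on it.

Measured so far in a functional assay on A549 cells (Homo sapiens) for cytotoxicity, read by XTT assay, with a stated time of 24 h; on this read-out higher numbers stand for weaker inhibition and lower numbers for stronger inhibition:

compound 1, `Cc1ccc(/C=N/NC(=O)CSc2nnnn2C)cc1`: 3160000 nM
compound 2, `COc1ccc(/C=N/NC(=O)CSc2nnnn2C)cc1`: the value of compound 2 is a limit of the assay, > 10000000 nM
compound 3, `COc1cccc(/C=N/NC(=O)CSc2nnnn2C)c1`: the value of compound 3 is likewise a limit of the assay, > 10000000 nM

Compound 1 is the only one of the three with a number in this assay. Going from compound 2 to compound 1 the change is methyl in place of methoxy on an aromatic carbon and the step in this assay is an at least 3.1-fold lower number from compound 2 to compound 1 (0.50 log units; beyond the scatter). The step is only a bound because of the limit of > 10000000 nM in this assay, at which 2 of the 3 values shown sit.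

Compound 4, `Cc1cccc(/C=N/NC(=O)CSc2nnnn2C)c1`, has not been measured in this assay. It is reached from compound 3 by methyl in place of methoxy on an aromatic carbon. Going by the values given here, this is the same kind of change as the one from compound 2 to compound 1; what differs is the surrounding: in compound 4 the methyl stands meta to a large group, in compound 1 para to a large group. The difference between the cores of compound 2 and compound 3 is not broken down here.

Given the single measured instance of this change, compound 4 is expected to move from compound 3 by about an at least 2.0-fold lower number from compound 3 to compound 4 (0.30 log units; that floor lies within the scatter) in this assay, with the reservation that both compound 2 and compound 3 sit at the limit of the assay and the true size of the measured step is unknown. The estimate for compound 4 in this assay is therefore 5000000 nM, with a likely range from 1500000 nM to 20000000 nM, and a real chance that only a limit is reported again.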

Compound 4, half-maximal inhibitory concentration: 2000000 nM
Beside the measured number, compound 4's estimate is 2.5-fold (0.40 log units) above it, and the stated range covers the measured number.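

In this assay, methyl in place of methoxy on an aromatic carbon again gives a lower number, here an at least 5.0-fold lower number from compound 3 to compound 4 (0.69 log units; beyond the scatter), with the methyl meta to a large group. The direction of the change therefore holds on both cores shown, which is as far as the transfer can be claimed: the same change on two cores in this assay, an at least 3.1-fold lower number (0.50 log units; beyond the scatter) from compound 2 to compound 1 and an at least 5.0-fold lower number (0.69 log units; beyond the scatter) from compound 3 to compound 4; the limit leaves it open whether they differ. The sizes of the two steps cannot be read as true sizes or ranked against each other, and two cores do not establish a rule for the wider series, because each step starts from a compound that gives only a limit of the assay: the limit of > 10000000 nM in this assay, at which 2 of the 4 values shown sit.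

The compounds shown leave open whether a hydroxyl, an amine, a carboxylic acid or a longer chain on the same aromatic carbon would behave like methyl or like methoxy in this assay. Also open, on these data alone, is whether any change to the shared core gives numbers well below those of the two compounds with a measured value, where compound 1 gives 3160000 nM and compound 4 gives 2000000 nM.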